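Unsaturation restored in the amide side chain of compound 3

The compounds below may be only part of what the source reports. "The series", "measured", "known", "first", "only" and "open" are said of these compounds alone.

The shared core of compound 1 `CCCc1cc(N)c2cc(NC(=O)/C=C/c3ccc(Cl)cc3)ccc2n1` carries an amide on a carbonyl carbon, and in an assay on isolated protein for displacement of a labelled ligand from melanin-concentrating hormone receptor 1 (Homo sapiens) (a lower number here means a stronger inhibitor, a higher number a weaker inhibitor), compound 1 gives 6 nM. Among the compounds with values here, compound 2 `CCCc1cc(N)c2cc(NC(=O)/C=C/c3ccc(O)cc3)ccc2n1` differs only by hydroxy in place of chloro on an aromatic carbon, and in this assay compound 2 gives 1100 nM; that step, a 180-fold higher number from compound 1 to compound 2 (2.26 log units; beyond the scatter), is the single change for which two measured neighbours exist. Compound 3 `CCCc1cc(N)c2cc(NC(=O)CCc3ccccc3)ccc2n1` has the highest number of the three, in this assay compound 3 gives 8300 nM.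

Compound 4 `CCCc1cc(N)c2cc(NC(=O)/C=C/c3ccccc3)ccc2n1` is built from compound 3 by the change (2-phenylethenyl in place of phenethyl on a carbonyl carbon). Within the data shown here, no measured pair isolates this change, so the measured step between compound 1 and compound 2 does not speak to it directly. What the values show is that compound 1 and compound 2, which both carry the 2-phenylethenyl group, sit well below compound 3, while compound 4 lacks the chloro that gives compound 1 its low number. A large drop is therefore expected, landing between the values of compound 2 and compound 1: for compound 4 the expected step is a 140-fold lower number from compound 3 to compound 4 (2.14 log units; beyond the scatter), and its value in this assay is estimated at 60 nM, within a range from 15 nM to 400 nM.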

Compound 4, half-maximal inhibitory concentration: 1000 nM
Compound 4: middle estimate off by 17-fold (1.22 log units), on the low side; the measured number lies above the stated range.
By their numbers in this assay, from the lowest: compound 1; then compounds 4 and 2 (each within the scatter of the next); then compound 3.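

With the ring left unsubstituted, 2-phenylethenyl in place of phenethyl on a carbonyl carbon gives an 8.3-fold lower number from compound 3 to compound 4 (0.92 log units; beyond the scatter) in this assay. This shows that the double bond on its own has a measurable but modest effect on the number at this position. Compound 4 also supplies the unsubstituted reference that the earlier pair lacked: removing the chloro gives a 170-fold higher number from compound 1 to compound 4 (2.22 log units; beyond the scatter) and hydrogen in place of hydroxy gives a 1.1-fold lower number from compound 2 to compound 4 (0.04 log units; within the scatter), so the large difference between compound 1 and compound 2 reflects the low number that goes with chloro, while hydroxy and hydrogen cannot be told apart in this series.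

The compounds shown leave open whether fluoro, bromo, methyl or methoxy on that ring would match chloro, and whether chloro would lower the number to the same extent on the saturated phenethyl chain. No measurement presented here accounts for why either the double bond or the chloro changes the number as it does.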